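The source may hold more compounds than are shown below. What is called first, only, known or untested is meant among the compounds shown, and "the series" means these compounds.

In a functional assay on HepG2 cells (Homo sapiens) for antiproliferative activity, read by MTT assay, with a stated time of 48 h (a lower number here means a stronger inhibitor, a higher number a weaker inhibitor), compound 1 `COc1ccc(N(C)c2ccnc(Cl)n2)cc1OCCC[Se]C#N` gives 5150 nM and compound 2 `COc1ccc(N(C)c2cc(C)nc(C)n2)cc1` gives 824 nM while compound 3 `COc1ccc(N(C)c2cc(C)nc(C)n2)cc1Cl` gives 787 nM on the same read-out. Compound 3 thus sits level with compound 2 within the scatter, and both numbers lie well under that of compound 1.

Compound 4 `COc1ccc(N(C)c2cc(C)nc(C)n2)cc1O` has not yet been measured. It departs from compound 3 by hydroxy in place of chloro on an aromatic carbon with hydroxy in place of chloro on an aromatic carbon, ortho to a methoxy group.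

Among the measured compounds shown here, only one measured step bears on this place: a 1.0-fold lower number from compound 2 to compound 3 (0.02 log units; within the scatter) for chloro in place of hydrogen, and it lies within the scatter. For the measured compounds named here, no measured compound carries a hydroxy there, so the data offer no direct guide to this exchange, and the range has to stay wide. A step beyond the scatter is therefore not expected in this assay and the estimated change is a 1.1-fold lower number from compound 3 to compound 4 (0.05 log units; within the scatter) in either direction at most modest. Compound 4 is estimated at 700 nM with an expected range from 230 nM to 2200 nM in this test.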

Compound 4, half-maximal inhibitory concentration: 112 nM
For compound 4 the middle estimate is 6.3-fold (0.80 log units) above the measured one, outside the stated range (below it).
By their numbers in this assay, from the lowest: compound 4; then compounds 3 and 2 (each within the scatter of the next); then compound 1.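

In this assay this position, on an aromatic carbon ortho to a methoxy group, turns out to respond to substitution: hydroxy in place of chloro gives a 7.0-fold lower number from compound 3 to compound 4 (0.85 log units; beyond the scatter) and hydroxy in place of hydrogen gives a 7.4-fold lower number from compound 2 to compound 4 (0.87 log units; beyond the scatter). The earlier step between hydrogen and chloro, a 1.0-fold lower number from compound 2 to compound 3 (0.02 log units; within the scatter), had shown no separation at this place, so the change in number appears only with hydroxy, which brings a hydrogen-bond donor and a hydrogen-bond acceptor where chloro has neither. Nothing measured here explains why the hydroxy compound stands apart.

Open, going by these compounds, is whether another group at this place, such as an amine, a carboxylic acid or a longer chain, would match hydroxy. Also open, on these data alone, is whether the gain would carry over to the core of compound 1, which differs in more than one place.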